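Working notes: removing the chloro group from compound 2

The source may report more compounds than this note shows. Statements on the series, on what has been measured and on what is new or still open speak of the compounds shown alone.

In a functional assay on T98G cells (Homo sapiens) for cytotoxicity, read by MTT assay, with a stated time of 48 h (on this read-out higher numbers stand for weaker inhibition and lower numbers for stronger inhibition), compound 1 (`CC(=NNC(=S)Nc1ccccc1)c1ccccn1`) reads 6.8 nM and compound 2 (`C/C(=N\NC(=S)Nc1ccccc1Cl)c1ccccn1`) reads 1.1 nM on the same test. Compound 2 holds the lower of the two numbers, and the gap between them lies beyond the scatter. Still unmeasured is compound 3 (`C/C(=N\NC(=S)Nc1ccccc1)c1ccccn1`), which has hydrogen in place of chloro on an aromatic carbon ortho to a large group. Among the measured compounds shown here, no measured pair isolates this change, so the expectation rests on little evidence. For the measured compounds named here, the only other number in hand, compound 1 at 6.8 nM for this series, points upward from compound 2. A move to a higher number is expected, with the estimated step of a 4.5-fold higher number from compound 2 to compound 3 (0.66 log units; beyond the scatter) lying beyond the scatter. For compound 3 the estimate in this assay is 5 nM with an expected range from 1.8 nM to 14 nM on repeat measurement.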

Compound 3, half-maximal inhibitory concentration: 6.81 nM
Compound 3: the middle estimate sits 1.4-fold (0.13 log units) below what was measured; low and high end bracket the measured number.
By their numbers in this assay, from the lowest: compound 2; then compounds 1 and 3 (each within the scatter of the next).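

In this assay, a single matched pair now isolates the chloro group on this aromatic carbon: hydrogen in its place gives a 6.2-fold higher number from compound 2 to compound 3 (0.79 log units; beyond the scatter), so the position responds to this change, and compound 2 holds the lower number. Drawing the double bond as E rather than without a configuration gives a 1.0-fold higher number from compound 1 to compound 3 (0.00 log units; within the scatter), so the two entries read alike on this test. The only thing that separates those two compounds is this: the fact that one of compounds 1 and 3 is drawn with a defined configuration and the other without, at the place where they differ

The compounds shown leave open whether another group on this aromatic carbon, such as fluoro, methoxy or an amine, would stay close to compound 2 or to compound 3. They also leave open whether chloro gives a similar step on another carbon of that ring, and how the Z form of the double bond reads.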